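This account rests on a few compounds, and the source may have more. Where it says the series, first, only, none or still open, it means among the compounds named here.

Measured so far:
Compound 1, `CCCC(=O)OCCCCOC(=O)c1ccc(C(=O)Nc2ccc3c(c2)C(C)(C)CCC3(C)C)cc1`: 92600 nM
Compound 2, `CCCC(CCC)C(=O)OCCCCOC(=O)c1ccc(C(=O)Nc2ccc3c(c2)C(C)(C)CCC3(C)C)cc1`: > 1000000 nM

Both values come from a functional assay on K562 cells (Homo sapiens) for inhibition, read by MTT assay, with a stated time of 48 h; a lower number here means a stronger inhibitor, a higher number a weaker inhibitor. Compound 1 gives 92600 nM in this assay, a weak result. Compound 2 gives only > 1000000 nM in this assay, which is a limit of the measurement and not a number. Compound 2 therefore stands at the limit of > 1000000 nM in this assay, at which 1 of the 2 values shown sits, the weakest position the numbers shown can express.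

Compound 3, `CCCC(=O)OCCOC(=O)c1ccc(C(=O)Nc2ccc3c(c2)C(C)(C)CCC3(C)C)cc1`, has not yet been measured in this assay. It differs from compound 2 by (propylcarbonyl)oxy in place of 2-(((1-propylbutyl)carbonyl)oxy)ethyl on a saturated chain carbon, two bonds along the chain from an oxygen next to a carbonyl group. Among the compounds with values here, the only measured step that bears on this is an at least 10-fold higher number from compound 1 to compound 2 (1.03 log units; beyond the scatter), which runs in the opposite direction: there the branched 1-propylbutyl group replaced propyl and the number rose out of the measurable range. Within the data shown here, compound 3 returns to the propyl ester of compound 1, while also shortening the chain between the two ester oxygens, a change no measured pair informs. Compound 3 is therefore expected to fall back toward compound 1, with an at least 10-fold lower number from compound 2 to compound 3 (1.00 log units; beyond the scatter), giving an estimate of 100000 nM, ranging from 30000 nM to 400000 nM.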

Compound 3, half-maximal inhibitory concentration: 18600 nM
The estimate for compound 3 lay 5.4-fold (0.73 log units) above the measured number; the whole stated range lies above it.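

With the propyl ester kept, the chain alone changes from 2-((propylcarbonyl)oxy)ethyl to the shorter (propylcarbonyl)oxy, and in this assay this gives a 5.0-fold lower number from compound 1 to compound 3 (0.70 log units; beyond the scatter), so the length of this chain matters as well as the ester group at its end, which was all that the earlier pair varied. The larger step, an at least 53-fold lower number from compound 2 to compound 3 (1.73 log units; beyond the scatter), replaces 2-(((1-propylbutyl)carbonyl)oxy)ethyl and so changes the ester group and the chain together, and it cannot show how much of the gain belongs to each. Its size also rests on a value that is a limit of the assay and not a number: the limit of > 1000000 nM in this assay, at which 1 of the 3 values shown sits.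

The compounds shown leave open how the 1-propylbutyl ester behaves on the shorter chain, and whether a chain shorter still would continue the gain seen with compound 3, which at 18600 nM is the strongest of the three. They also leave open whether the ester group at the end of the chain is needed at all, or whether a carboxylic acid or an amine could take its place.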